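Adding an Amino Link to Compound 3's Side-Chain Carbonyl

A few compounds are considered here, and "the series" means these few. Any claim that something is new, unique, unknown or untested is made for them only; others in the source may bear on it.

Of the compounds shown here, three sharing one core have so far been tested in a functional assay on MDA-MB-231 cells (Homo sapiens) for inhibition, read by sulforhodamine B assay, with a stated time of 48 h; on this read-out lower numbers stand for higher toxicity in this test and higher numbers for lower toxicity in this test. Compound 1 `COc1cc(-c2nn(-c3cccc(NC(=O)c4cccc(C(F)(F)F)c4)c3)cc2-c2ccncc2)ccc1Cl` gives only a limit of the test, > 50000 nM. Compound 2 `COc1cc(-c2nn(-c3cccc(NC(=O)Nc4cccc(C(F)(F)F)c4)c3)cc2-c2ccncc2)ccc1Cl` gives 25500 nM. Compound 3 `COc1cc(-c2nn(-c3cccc(NC(=O)c4ccc(Cl)c(C(F)(F)F)c4)c3)cc2-c2ccncc2)ccc1Cl` likewise gives only a limit, > 32500 nM. Compound 3 therefore stands at a limit rather than at a number, and one of the other two values is a limit as well, so its place among the three cannot be fixed more closely. Of the measured steps, a step that the two limits leave unreadable from compound 1 to compound 3, and an at least 1.2-fold higher number from compound 2 to compound 3 (0.10 log units; that floor lies within the scatter).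

Compound 4 `COc1cc(-c2nn(-c3cccc(NC(=O)Nc4ccc(Cl)c(C(F)(F)F)c4)c3)cc2-c2ccncc2)ccc1Cl` differs from compound 3 in one place: (4-chloro-3-(trifluoromethyl)phenyl)amino in place of 4-chloro-3-(trifluoromethyl)phenyl on a carbonyl carbon. The same kind of change, an amino-linked aryl group in place of a directly bound aryl group on the carbonyl carbon, has been seen once before, in an at least 1.9-fold lower number from compound 1 to compound 2 (0.29 log units; that floor lies within the scatter). On that basis a modest move towards a lower number is expected, though it may not rise beyond the scatter. Compound 4 is therefore expected to give about 20000 nM, within a range of 8000 nM to 50000 nM. That estimate would mean an expected at least 1.6-fold lower number from compound 3 to compound 4 (0.21 log units; that floor lies within the scatter).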

Compound 4, concentration lethal to 50% of the cells: 13300 nM
Compound 4: the middle estimate sits 1.5-fold (0.18 log units) above what was measured; the range from low to high includes it.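

Placing the amino link on the carbonyl carbon now gives a change that clears the scatter, an at least 2.4-fold lower number from compound 3 to compound 4 (0.38 log units; beyond the scatter), whereas the floor of the earlier step of this kind, an at least 1.9-fold lower number from compound 1 to compound 2 (0.29 log units; that floor lies within the scatter), did not. With the amino link already present, chloro in place of hydrogen on an aromatic carbon gives a 1.9-fold lower number from compound 2 to compound 4 (0.28 log units; within the scatter), so this change alone cannot be told apart from repeat variation. The two changes together give an at least 3.7-fold lower number from compound 1 to compound 4 (0.57 log units; beyond the scatter), with the same direction seen in both amino-link pairs.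

As far as these compounds go, the full size of the step from compound 3 stays open, because compound 3 gives only a limit: the limit of > 32500 nM in this assay, at which 1 of the 4 values shown sits. Also open, from the compounds shown here alone, is whether a methylene link or an oxygen link in the same place on the carbonyl carbon would lower the number as the amino link does.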